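Hydroxy on the Methyl: Expected Drop in Lipophilicity

The source may report more compounds than this note shows. Statements on the series, on what has been measured and on what is new or still open speak of the compounds shown alone.

Among the compounds with values here, compound 2 `CC[C@@H](Nc1c(C#N)c(-c2ccc(-c3cccc(C)c3)cc2)nc2cnccc12)C(N)=O` gives 3 in a physicochemical assay for lipophilicity, read by HPLC, at pH 7.5 (on this read-out lower numbers stand for lower lipophilicity and higher numbers for higher lipophilicity), the higher of the two numbers known; compound 1 `CCOc1ccccc1-c1ccc(-c2nc3cnccc3c(NC(C)C(=O)O)c2C#N)cc1` stands at 2.1, a gap beyond the usual scatter. Compound 3 `CC[C@@H](Nc1c(C#N)c(-c2ccc(-c3cccc(CO)c3)cc2)nc2cnccc12)C(N)=O` has not yet been measured in this assay. It differs from compound 2 in one place: hydroxy in place of hydrogen on a saturated chain carbon bound to an aromatic carbon. Within the data shown here, no measured pair shows this change, so the step is an expectation only, downward and beyond the scatter, estimated at a number 1.20 log units lower from compound 2 to compound 3 (beyond the scatter). For compound 3 the expected value in this assay is 1.8, in a range from 1.3 to 2.3.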

Compound 3, distribution coefficient: 2
Beside the measured number, compound 3's estimate is 0.20 log units below it, and the stated range covers the measured number.
By their numbers in this assay, from the lowest: compounds 3 and 1 (each within the scatter of the next); then compound 2.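

In this assay, within the data shown here, the change from 3-methylphenyl to 3-(hydroxymethyl)phenyl gives a number 1.00 log units lower from compound 2 to compound 3 (beyond the scatter) and is the first measured step at this position, since the earlier compounds offered no pair differing in one place. The step is modest and beyond the scatter, so hydroxy in place of hydrogen on this saturated chain carbon bound to an aromatic carbon clearly registers on this read-out. Nothing available explains the size of the step.

From the compounds shown here alone, whether an amine, a carboxylic acid or a longer chain in the same place would give a similar step remains open. So does whether hydroxy gives a step of this size on other carbons of these compounds.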